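The source may hold more compounds than are shown below. What is called first, only, known or untested is meant among the compounds shown, and "the series" means these compounds.

Working notes on the series, all read in a functional assay on HT-29 cells (Homo sapiens) for antiproliferative activity, with a stated time of 48 h; a lower number here means that less compound is needed, a higher number that more compound is needed for the effect. Compound 1 `O=C(CCCCCCC(=O)Nc1ccc(O)cc1)NO` gives 15000 nM, compound 2 `O=C(CCCCCCC(=O)Nc1cccc(Cl)c1)NO` gives 1000 nM and compound 3 `O=C(CCCCCCC(=O)Nc1ccc(I)cc1)NO` gives 950 nM. Compound 3 sits level with compound 2 within the scatter, and both numbers lie well under that of compound 1.

The next structure is compound 4 `O=C(CCCCCCC(=O)Nc1ccc([N+](=O)[O-])cc1)NO`, which keeps the shared core and differs from compound 3 at one group: nitro in place of iodo on an aromatic carbon. This is nitro in place of iodo on an aromatic carbon, para to a large group.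

Among the measured compounds shown here, one measured step bears on this place: a 16-fold lower number from compound 1 to compound 3 (1.20 log units; beyond the scatter), a large step beyond the scatter for iodo in place of hydroxy. It shows that a change at this place can move the number strongly. However, it starts from hydroxy, and no measured compound carries nitro, so it gives no direction for the new group. The values of compound 2 and compound 3 offer no further guide to nitro. No step beyond the scatter is therefore expected in this assay, though a slight move to a higher number is thought somewhat more likely than a lower one. The estimate means a 1.6-fold higher number from compound 3 to compound 4 (0.20 log units; within the scatter), an expected step of modest size. For compound 4 the estimated value is 1500 nM, with an expected range from 500 nM to 5000 nM.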

Compound 4, half-maximal effective concentration: 76000 nM
Compound 4: the middle estimate sits 51-fold (1.70 log units) below what was measured, and the stated range ends below it.
By their numbers in this assay, from the lowest: compounds 3 and 2 (each within the scatter of the next); then compound 1; then compound 4.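

In this assay, among the compounds shown here, the place on the aromatic carbon para to a large group turns out to move the number in both directions: nitro in place of iodo gives an 80-fold higher number from compound 3 to compound 4 (1.90 log units; beyond the scatter) and so reverses the direction of the only earlier step at this place. Nitro also stands apart from hydroxy, with a 5.1-fold higher number from compound 1 to compound 4 (0.70 log units; beyond the scatter) as the smaller of the two new steps, so the three groups at this place give three clearly separated numbers, with iodo lowest, hydroxy in the middle and nitro highest. Nothing in hand accounts for this order, and the count of heavy atoms or hydrogen-bond acceptors that changes with nitro remains a description of the swap and not an explanation of the step.

From the compounds shown here alone, three groups at one place cannot show what governs the order, so it remains open whether an amino group, a methoxy group or a carboxylic acid on this carbon would fall near compound 3 or near compound 4. Going by these compounds, it is equally open whether the large step from iodo to nitro would hold with a longer chain between the hydroxamic acid end and the amide.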